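Sulfonyl substitution on an indolyl enone scaffold: propyl to methoxyphenyl

The source may report more compounds than this note shows. Statements on the series, on what has been measured and on what is new or still open speak of the compounds shown alone.

Measured compounds:
compound 1, `CC(C)(C)c1ccc(S(=O)(=O)n2cc(/C=C/C(=O)c3ccncc3)c3ccccc32)cc1` — 24000 nM; "dose-dependent effect" (no number reported) (2 entries)
compound 2, `CCCS(=O)(=O)n1cc(/C=C/C(=O)c2ccncc2)c2ccccc21` — 52400 nM

This account concerns two sulfonylated compounds sharing one core and a third not yet tested. In a functional assay on MCF7 cells (Homo sapiens) for antiproliferative activity, read by MTT assay, with a stated time of 48 h (on this read-out lower numbers stand for stronger inhibition and higher numbers for weaker inhibition), compound 1 gives 24000 nM; "dose-dependent effect" (no number reported) (2 entries), and the further entries of compound 1 are summarised as the several entries of compound 1 in this assay, 24000 nM; "dose-dependent effect" (no number reported) (2 entries). In this assay compound 2 gives 52400 nM, the only number shown for it, with a further entry that carries no single number; it stands as the higher of the two values shown. Among the measured compounds shown here, no step between measured compounds is given, so the two numbers are simply reported side by side.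

Compound 3, `COc1ccc(S(=O)(=O)n2cc(/C=C/C(=O)c3ccncc3)c3ccccc32)cc1`, differs from compound 2 by one change: 4-methoxyphenyl in place of propyl on a sulfonyl sulfur. Judged from the two values shown, a modest move toward lower numbers is expected, since compound 1 gives 24000 nM; "dose-dependent effect" (no number reported) (2 entries). The estimated step of a 1.9-fold lower number from compound 2 to compound 3 (0.27 log units; within the scatter) is expected to be small and close to the edge of the scatter. Compound 3 is therefore expected to give 28000 nM, within 10000 nM to 80000 nM.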

Compound 3, half-maximal inhibitory concentration: 65800 nM
For compound 3 the middle estimate is 2.4-fold (0.37 log units) below the measured one; the measured number falls inside the stated range.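

In this assay, among the compounds shown here, the first step that can be read at this position is a 1.3-fold higher number from compound 2 to compound 3 (0.10 log units; within the scatter) and it shows that 4-methoxyphenyl and propyl on a sulfonyl sulfur, whose other neighbour is aromatic nitrogen, cannot be told apart in this read-out, although the change brings in a six-membered aromatic ring and a hydrogen-bond acceptor. An aromatic ring on the sulfur therefore does not by itself go with a lower number, for among the two compounds that carry a substituted phenyl there, compound 1 gives 24000 nM; "dose-dependent effect" (no number reported) (2 entries) and compound 3 gives 65800 nM. Nothing measured on these compounds accounts for this result.

The compounds shown leave open how the read-out responds to an unsubstituted phenyl, a benzyl or a longer chain such as hexyl on the sulfonyl sulfur. They also leave open whether an amine or a carboxylic acid in place of the methoxy group on that phenyl ring would move the number beyond the scatter in either direction.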